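Swapping a butoxy chain for a 2-methylphenyl ring on a benzamide

A few compounds are considered here, and "the series" means these few. Any claim that something is new, unique, unknown or untested is made for them only; others in the source may bear on it.

Compound 1 `CCCCOc1cccc(C(=O)Nc2cccc(C(=O)O)c2)c1` and compound 2 `O=C(O)c1cccc(NC(=O)c2ccc(OCc3ccccc3)cc2)c1` share an amide-linked benzoic acid core. In an assay on isolated protein for agonist activity at Bile acid receptor (Homo sapiens), read by TR-FRET, with a stated time of 3 h, in the absence of a further agent (on this read-out higher numbers stand for an effect only at larger amounts of compound and lower numbers for an effect already at smaller amounts), compound 1 gives 3150 nM, the higher of the two numbers; compound 2 gives 135 nM, a number far lower and well beyond the usual scatter. Compound 3 `Cc1ccccc1-c1cccc(C(=O)Nc2cccc(C(=O)O)c2)c1` has not yet been measured. It differs from compound 1 in one place: 2-methylphenyl in place of butoxy on an aromatic carbon. Going by the values given here, no measured pair shows this exact change, so the step from compound 1 to compound 3 is expected to be a 3.2-fold lower number from compound 1 to compound 3 (0.50 log units; beyond the scatter), a moderate move toward a lower number. For compound 3 the expected value is 1000 nM, within 250 nM to 4000 nM.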

Compound 3, half-maximal effective concentration: 68 nM
Compound 3: middle estimate off by 15-fold (1.17 log units), on the high side; the measured number lies below the stated range.
By their numbers in this assay, from the lowest: compounds 3 and 2 (each within the scatter of the next); then compound 1.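

In this assay, the aromatic carbon that carries butoxy in compound 1 proves highly responsive to what sits there, with 2-methylphenyl in its place giving a 46-fold lower number from compound 1 to compound 3 (1.67 log units; beyond the scatter) as a large step. An all-carbon ring with no hydrogen-bond acceptor can therefore replace this open chain and still bring the number down. Nothing available here explains the size of this step. The compounds shown leave open whether a plain phenyl ring, without the methyl, would do the same, and how an amine or a longer chain on this carbon would behave.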